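Working notes: from compound 2 to compound 4

The compounds below may be only part of what the source reports. "The series", "measured", "known", "first", "only" and "open" are said of these compounds alone.

Values in a functional assay on HeLa cells (Homo sapiens) for antiproliferative activity, read by MTT assay, with a stated time of 48 h; on this read-out higher numbers stand for weaker inhibition and lower numbers for stronger inhibition:
- compound 1 `Cc1ccc(-c2nn(-c3ccccc3)cc2C(Nc2nc3cc(C)c(C)cc3s2)c2c(O)ccc3ccccc23)cc1` gives 17800 nM
- compound 2 `Cc1cc2nc(NC(c3cn(-c4ccccc4)nc3-c3ccc([N+](=O)[O-])cc3)c3c(O)ccc4ccccc34)sc2cc1C` gives 14700 nM
- compound 3 `COc1ccc(-c2nn(-c3ccccc3)cc2C(Nc2nc3ccccc3s2)c2c(O)ccc3ccccc23)cc1` gives 9340 nM

Compound 2, at 14700 nM, cannot be separated from its neighbours: compound 1 and compound 3 both lie within the usual scatter of it, so it holds no firm rank against either.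

The next compound is compound 4 `COc1ccc2nc(NC(c3cn(-c4ccccc4)nc3-c3ccc([N+](=O)[O-])cc3)c3c(O)ccc4ccccc34)sc2c1`, which keeps the rest of compound 2 and changes one group: 6-methoxy-1,3-benzothiazol-2-yl in place of 5,6-dimethyl-1,3-benzothiazol-2-yl on an amine nitrogen. The change sits on an amine nitrogen, with 6-methoxy-1,3-benzothiazol-2-yl in place of 5,6-dimethyl-1,3-benzothiazol-2-yl.

Within the data shown here, no measured step covers this exchange directly. Among the measured compounds shown here, the only step available is a 1.2-fold lower number from compound 1 to compound 2 (0.08 log units; within the scatter). It concerns a different place, an aromatic carbon, and it stays within the scatter. For the measured compounds named here, compound 3, which carries neither of the two groups, gives 9340 nM and differs from compound 2 in more than one place, so it supplies no clean step. It does show that a different group on the amine nitrogen can come with a value within the scatter of compound 2.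

On this thin evidence, no step beyond the scatter is expected in this assay, in either direction. The expected step is a 1.2-fold lower number from compound 2 to compound 4 (0.07 log units; within the scatter). For compound 4 the estimated value is 12500 nM, with an expected range of 6000 nM to 26000 nM.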

Compound 4, half-maximal inhibitory concentration: 5540 nM
Compound 4: the middle estimate sits 2.3-fold (0.35 log units) above what was measured; the measured number lies below the stated range.
By their numbers in this assay, from the lowest: compounds 4, 3, 2 and 1 (each within the scatter of the next, the first and the last beyond it).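

In this assay, among these compounds, the amine nitrogen is the first place where a single exchange moves the number beyond the scatter. 6-Methoxy-1,3-benzothiazol-2-yl in place of 5,6-dimethyl-1,3-benzothiazol-2-yl gives a 2.7-fold lower number from compound 2 to compound 4 (0.42 log units; beyond the scatter), a modest step, whereas nitro in place of methyl on an aromatic carbon gave only a 1.2-fold lower number from compound 1 to compound 2 (0.08 log units; within the scatter), which stays within the scatter. Nothing measured here accounts for the step at the amine nitrogen.

The exchange removes two methyl groups and brings in one methoxy group in a single move, so the compounds shown do not say which of these carries the step, or whether the same exchange would give a step of similar size with methyl in place of nitro on the aromatic carbon, as in compound 1. Going by these compounds, it also remains open how the number would respond if the methoxy group of 6-methoxy-1,3-benzothiazol-2-yl gave way to a longer ether chain such as ethoxy, to a primary amine or to a carboxylic acid.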